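The source may hold more compounds than are shown below. What is called first, only, known or untested is meant among the compounds shown, and "the series" means these compounds.

Three compounds share one core and differ only in the aryl group attached to the carbonyl carbon. Compound 1 `COc1ccc(/C=C/c2cc(OC)cc(OC)c2/C=C/C(=O)c2ccc(Cl)c(Cl)c2)cc1` carries a 3,4-dichlorophenyl there, compound 2 `COc1ccc(/C=C/c2cc(OC)cc(OC)c2/C=C/C(=O)c2cccc(Br)c2)cc1` a 3-bromophenyl, and compound 3 `COc1ccc(/C=C/c2cc(OC)cc(OC)c2/C=C/C(=O)c2ccc(C)cc2C)cc1` a 2,4-dimethylphenyl. In a functional assay on A549 cells (Homo sapiens) for antiproliferative activity, read by MTT assay, with a stated time of 48 h (on this read-out higher numbers stand for weaker inhibition and lower numbers for stronger inhibition), compound 1 gives 5.9 ug/mL, compound 2 gives 8.1 ug/mL and compound 3 gives 0.3 ug/mL. Compound 2 thus stands at the highest of the three numbers: its nearest neighbour is compound 1, with a 1.4-fold higher number from compound 1 to compound 2 (0.14 log units; within the scatter), while its furthest is compound 3, with a 27-fold lower number from compound 2 to compound 3 (1.43 log units; beyond the scatter).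

Compound 4 `COc1ccc(/C=C/c2cc(OC)cc(OC)c2/C=C/C(=O)c2ccc(OC)cc2)cc1` arises from compound 2 by a single change: 4-methoxyphenyl in place of 3-bromophenyl on a carbonyl carbon. For the measured compounds named here, two measured steps bear on this. The step of a 1.4-fold higher number from compound 1 to compound 2 (0.14 log units; within the scatter) exchanges one halogen-bearing ring for another and changes little. The step of a 27-fold lower number from compound 2 to compound 3 (1.43 log units; beyond the scatter), and likewise a 20-fold lower number from compound 1 to compound 3 (1.29 log units; beyond the scatter), shows that leaving the halogen-bearing rings for a methyl-bearing ring lowers the number a great deal. Going by the values given here, the group entering compound 4 carries no halogen, which points towards a lower number, yet it also brings a hydrogen-bond acceptor that no measured compound has, so the size of the effect is uncertain. In this assay compound 4 is therefore expected to give about 3 ug/mL, somewhere between 0.5 ug/mL and 15 ug/mL. That estimate means a step of a 2.7-fold lower number from compound 2 to compound 4 (0.43 log units; beyond the scatter).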

Compound 4, half-maximal inhibitory concentration: 4.5 ug/mL
For compound 4 the middle estimate is 1.5-fold (0.18 log units) below the measured one, within the range that was stated.
By their numbers in this assay, from the lowest: compound 3; then compounds 4, 1 and 2 (each within the scatter of the next).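

The halogen on the ring is not what separates these compounds at the carbonyl carbon: in this assay, a 1.8-fold lower number from compound 2 to compound 4 (0.26 log units; within the scatter) and a 1.3-fold lower number from compound 1 to compound 4 (0.12 log units; within the scatter) are both small steps, so a ring with no halogen can give much the same number as the two halogen-bearing rings. Removing the halogen is therefore not enough to reach the low number of compound 3, as a 15-fold higher number from compound 3 to compound 4 (1.18 log units; beyond the scatter) shows that a second halogen-free ring stays far from it. Among the four compounds, the large steps all involve the 2,4-dimethylphenyl group of compound 3, and the hydrogen-bond acceptor that enters with 4-methoxyphenyl produces no step beyond the scatter from either halogen-bearing compound.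

Nothing available explains why the 2,4-dimethylphenyl group stands apart from the other three rings. The compounds shown also leave open whether a single methyl group on the ring would give the same low number, and how an ethyl group, an amine or a carboxylic acid on the ring would behave in this assay at this position.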